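The source may hold more compounds than are shown below. What is called first, only, known or untested is meant among the compounds shown, and "the series" means these compounds.

Measured in a functional assay on HT-29 cells (Homo sapiens) for antiproliferative activity, read by MTT assay, with a stated time of 72 h; a higher number here means a weaker inhibitor, a lower number a stronger inhibitor:
- compound 1 `CCOc1ccc(-c2sc(NC)nc2-c2cc(OC)c(OC)c(OC)c2)cc1`: 3.2 nM
- compound 2 `COc1cc(-c2nc(C)sc2-c2ccc(C)cc2)cc(OC)c1OC`: 722 nM
- compound 3 `COc1cc(-c2nc(C)sc2-c2ccc(C(F)(F)F)cc2)cc(OC)c1OC`: 396 nM

Compound 3 reads 396 nM and sits within the scatter of compound 2 at 722 nM, while compound 1 at 3.2 nM lies far lower than both.

The next molecule is compound 4 `CCOc1ccc(-c2sc(C)nc2-c2cc(OC)c(OC)c(OC)c2)cc1`, which puts ethoxy in place of trifluoromethyl on an aromatic carbon.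

For the measured compounds named here, only one measured step swaps a group at this place, a 1.8-fold lower number from compound 2 to compound 3 (0.26 log units; within the scatter), and it stays within the scatter. That swap did not involve ethoxy, so it is a weak guide. Compound 1 also carries ethoxy and reads 3.2 nM, but it differs from compound 4 elsewhere in the molecule, so it points the way without fixing the size.

A clear move towards a lower number is therefore expected in this assay, beyond the scatter, and the estimated change is a 6.6-fold lower number from compound 3 to compound 4 (0.82 log units; beyond the scatter). The estimate for compound 4 is 60 nM, with an expected range from 10 nM to 350 nM.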

Compound 4, half-maximal inhibitory concentration: 487 nM
For compound 4 the middle estimate is 8.1-fold (0.91 log units) below the measured one; measured number above the stated range.
By their numbers in this assay, from the lowest: compound 1; then compounds 3, 4 and 2 (each within the scatter of the next).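

In this assay, methyl, trifluoromethyl and ethoxy at this position all give numbers within the scatter of one another (a 1.2-fold higher number from compound 3 to compound 4 (0.09 log units; within the scatter); a 1.5-fold lower number from compound 2 to compound 4 (0.17 log units; within the scatter)), so with a methyl at the other place, ethoxy does not bring the low number of compound 1. For the compounds shown here, the large gap comes with the single change at that other place, where ethoxy stays fixed (a 150-fold higher number from compound 1 to compound 4 (2.18 log units; beyond the scatter)), so in this pair, methylamino versus methyl matters far more than any swap seen at the ethoxy position. Nothing given here bears on the cause of either result.

On these data alone, it remains open whether methyl or trifluoromethyl at this position would hold the low number when methylamino is present, since compound 1 shows that group only with ethoxy. As far as these compounds go, the effect of an amine, a hydroxyl or a longer chain such as butoxy at this position also remains open.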